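The source may report more compounds than this note shows. Statements on the series, on what has been measured and on what is new or still open speak of the compounds shown alone.

Of the compounds shown here, three built on one shared core have been measured in a functional assay on A549 cells (Homo sapiens) for inhibition, read by MTT assay, with a stated time of 72 h; on this read-out higher numbers stand for weaker inhibition and lower numbers for stronger inhibition. Compound 1 `COc1cc2c(Oc3ccc(NC(=O)c4nn(-c5ccccc5OC(F)(F)F)c(=O)cc4C)cc3F)ccnc2cc1OCCCN1CCCC1` gives 140 nM in this assay. Compound 2 `COc1cc2c(Oc3ccc(NC(=O)c4nn(-c5ccccc5OC(F)(F)F)c(=O)cc4C)cc3F)ccnc2cc1OCCCN1CCCCC1` gives 120 nM. Compound 3 `COc1cc2c(Oc3ccc(NC(=O)c4nn(-c5ccccc5OC(F)(F)F)c(=O)cc4C)cc3F)ccnc2cc1OCCCN1CCN(C)CC1` gives 130 nM. These three differ only in the saturated ring at the end of the chain, and the steps among them are small: a 1.2-fold lower number from compound 1 to compound 2 (0.07 log units; within the scatter), a 1.1-fold lower number from compound 1 to compound 3 (0.03 log units; within the scatter), and a 1.1-fold higher number from compound 2 to compound 3 (0.03 log units; within the scatter). Compound 3 therefore stands within the scatter of both of the others, and none of the three can be told apart on these numbers.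

Compound 4 `COc1cc2c(Oc3ccc(NC(=O)c4nn(-c5ccc(F)c(F)c5)c(=O)cc4C)cc3F)ccnc2cc1OCCCN1CCN(C)CC1` has not yet been measured. It differs from compound 3 in a different place: 3,4-difluorophenyl in place of 2-(trifluoromethoxy)phenyl on an aromatic nitrogen. Among the compounds with values here, none of the measured steps touches this position; all three concern the ring at the chain end, so they do not bear directly on the step from compound 3 to compound 4. What they do show is that the core, with the group on the aromatic nitrogen kept the same, holds its numbers steady in this assay across several chain-end rings. Within the data shown here, with no measured step at the changed position, the expectation can only rest on compound 3, which gives 130 nM. The step expected from compound 3 to compound 4 is a 1.2-fold higher number from compound 3 to compound 4 (0.06 log units; within the scatter), with a wide range. Compound 4 is therefore expected to give 150 nM in this assay, between 50 nM and 500 nM.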

Compound 4, half-maximal inhibitory concentration: 130 nM
Compound 4: middle estimate off by 1.2-fold (0.06 log units), on the high side, and the stated range covers the measured number.
By their numbers in this assay, from the lowest: compounds 2, 3, 4 and 1 (each within the scatter of the next).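

Within the data shown here, the earlier compounds changed only the saturated ring at the chain end, so this is the first reading at the aromatic nitrogen: in this assay, 3,4-difluorophenyl in place of 2-(trifluoromethoxy)phenyl gives no change at the digits printed from compound 3 to compound 4 (within the scatter). This is not a trivial swap on paper, since the leaving group has 11 heavy atoms and 1 hydrogen-bond acceptor, while the entering group has 8 heavy atoms and 0 hydrogen-bond acceptors, yet the read-out holds, so the number at this position does not depend on keeping the 2-(trifluoromethoxy)phenyl group, at least for this one replacement. No measurement offered here gives a reason for that outcome, so the result stands as an observation only.

A single replacement cannot show how far this tolerance reaches, and it leaves open whether a plain phenyl ring, or a phenyl ring carrying an amine or a carboxylic acid, would hold the number as well. It also leaves open whether 3,4-difluorophenyl would behave the same way with a pyrrolidin-1-yl or piperidin-1-yl ring at the chain end.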